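Adding a Second Methoxy Group to Compound 3

This account rests on a few compounds, and the source may have more. Where it says the series, first, only, none or still open, it means among the compounds named here.

Compound 1 `O=c1ccoc(/C=C/c2ccccc2)c1` and compound 2 `COc1ccc(/C=C/c2cc(=O)cco2)cc1` share one core. In a functional assay on U-251 cells (Homo sapiens) for inhibition, read by sulforhodamine B assay, with a stated time of 48 h (on this read-out higher numbers stand for weaker inhibition of growth and lower numbers for stronger inhibition of growth), compound 1 gives 285 uM and compound 2 gives 278 uM. The change between them, (methoxy in place of hydrogen on an aromatic carbon), made a 1.0-fold lower number from compound 1 to compound 2 (0.01 log units; within the scatter). Compound 3 `COc1ccc(/C=C/C2CC=CC(=O)O2)cc1` is built on a different core; the difference between the two cores is not broken down here. In this assay compound 3 gives 20.6 uM, a number well below those of compounds 1 and 2. Compound 4 `COc1ccc(/C=C/C2CC=CC(=O)O2)cc1OC` has not yet been measured. It differs from compound 3 by methoxy in place of hydrogen on an aromatic carbon, the same kind of change seen earlier, though here the new group sits ortho to a methoxy group and meta to a group of 9 heavy atoms rather than para to that group. Because the earlier change gave a 1.0-fold lower number from compound 1 to compound 2 (0.01 log units; within the scatter), a step of similar size is expected, a 1.1-fold lower number from compound 3 to compound 4 (0.06 log units; within the scatter). Compound 4 is therefore estimated at 18 uM, between 6 uM and 50 uM.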

Compound 4, concentration for growth inhibition (reported as GI): 23.9 uM
Compound 4: middle estimate off by 1.3-fold (0.12 log units), on the low side, within the range that was stated.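

In this assay, methoxy in place of hydrogen on an aromatic carbon gave a 1.2-fold higher number from compound 3 to compound 4 (0.06 log units; within the scatter). Set beside the same change on the other core, the two steps agree: the same change on two cores in this assay, a 1.0-fold lower number (0.01 log units; within the scatter) from compound 1 to compound 2 and a 1.2-fold higher number (0.06 log units; within the scatter) from compound 3 to compound 4, 1.2-fold (0.08 log units) apart, within the scatter of two such steps. This shows that the change carried across these two cores with no step beyond the scatter on either, but it does not show what the methoxy group would do on any other core, or in any other place than those in compound 2 and compound 4.

The compounds shown leave open whether a different group in these places, such as an amine or a carboxylic acid, would give a larger step. The same question stands for a longer chain, such as ethoxy.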